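The source may report more compounds than this note shows. Statements on the series, on what has been measured and on what is new or still open speak of the compounds shown alone.

Compound 1 `Oc1nc(-c2ccc(C(F)(F)F)cc2)cc2ccccc12`: 87300 nM
Compound 2 `Cc1ccc2c(S)nc(-c3ccccc3)cc2c1`: 34700 nM; 56200 nM (2 entries)
Compound 3 `COc1ccc(-c2cc3cc(C)ccc3c(N3CCN(C)CC3)n2)cc1`: 7940 nM

In a functional assay on SK-OV-3 cells (Homo sapiens) for cytotoxicity (a lower number here means a stronger inhibitor, a higher number a weaker inhibitor), compound 3 has the lower of the two single numbers, 7940 nM, and the gap to compound 1 at 87300 nM lies beyond the scatter. Compound 2 has two entries rather than one number, (the several entries of compound 2 in this assay, 34700 nM; 56200 nM (2 entries)), and both are higher than the number for compound 3.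

Compound 4 `Cc1ccc2c(N3CCN(C)CC3)nc(-c3ccc(Cl)cc3)cc2c1` differs from compound 3 in one group: chloro in place of methoxy on an aromatic carbon, turning 4-methoxyphenyl into 4-chlorophenyl (chloro in place of methoxy on an aromatic carbon). Among the compounds with values here, no measured pair shows what this swap does, so no shift beyond the scatter is expected, and the estimated change is a 1.2-fold lower number from compound 3 to compound 4 (0.09 log units; within the scatter) in this assay. For compound 4 the expected value is 6500 nM, with an estimated range of 2200 nM to 19000 nM.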

Compound 4, half-maximal inhibitory concentration: 5750 nM
The estimate for compound 4 lay 1.1-fold (0.05 log units) above the measured number; the range from low to high includes it.
By their numbers in this assay, from the lowest: compounds 4 and 3 (each within the scatter of the next); then compound 1.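

In this assay, within the data shown here, chloro in place of methoxy gives a 1.4-fold lower number from compound 3 to compound 4 (0.14 log units; within the scatter), and this is the first pair here that differs in only one place. At this place on the aromatic ring, the two compounds cannot be told apart, so this assay does not separate the two groups. Nothing at hand bears on why they read alike.

As far as these compounds go, whether an amine, a carboxylic acid or a longer chain at this same place would also fall within the scatter remains open. So does whether this swap would behave the same way on a different core.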